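A trifluoromethyl swap on the triazole of compound 3

The source may report more compounds than this note shows. Statements on the series, on what has been measured and on what is new or still open speak of the compounds shown alone.

Three compounds share one core and differ only in the group at the end of the methoxy arm. In a functional assay for agonist activity at Bombesin receptor subtype-3 (Homo sapiens) (a higher number here means that more compound is needed for the effect, a lower number that less compound is needed), compound 1 `CCC(C)(C)Cc1c[nH]c(CCc2ccc(-c3ccccc3OCC(=O)O)cc2)n1` gives 54 nM, compound 2 `CCC(C)(C)Cc1c[nH]c(CCc2ccc(-c3ccccc3OCc3ncn[nH]3)cc2)n1` gives 172 nM, and compound 3 `CCC(C)(C)Cc1c[nH]c(CCc2ccc(-c3ccccc3OCc3nc(N)n[nH]3)cc2)n1` gives 78 nM. Compound 3 holds the second highest of the three numbers: compound 1 lies within the scatter of it, while compound 2 sits beyond the scatter, as a 2.2-fold lower number from compound 2 to compound 3 (0.34 log units; beyond the scatter) shows. Compound 4 `CCC(C)(C)Cc1c[nH]c(CCc2ccc(-c3ccccc3OCc3nc(C(F)(F)F)n[nH]3)cc2)n1` arises from compound 3 by trifluoromethyl in place of amino on an aromatic carbon. Within the data shown here, no measured step puts a trifluoromethyl on this ring, so only a 2.2-fold lower number from compound 2 to compound 3 (0.34 log units; beyond the scatter) touches the position: the amino brought a modest gain over hydrogen there, and compound 4 gives that amino up. A modest move back toward the number of compound 2 is therefore the most that the data support, with no step beyond the scatter ruled out in either direction. Compound 4 is expected to give about 150 nM, in a range from 60 nM to 400 nM. The expected step is a 1.9-fold higher number from compound 3 to compound 4 (0.28 log units; within the scatter).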

Compound 4, half-maximal effective concentration: 129 nM
Beside the measured number, compound 4's estimate is 1.2-fold (0.07 log units) above it; measured number inside the range.
By their numbers in this assay, from the lowest: compounds 1, 3, 4 and 2 (each within the scatter of the next, the first and the last beyond it).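

In this assay, trifluoromethyl on this carbon of the triazole gives a result that falls within the scatter of both earlier groups: replacing amino gives a 1.7-fold higher number from compound 3 to compound 4 (0.22 log units; within the scatter), and replacing hydrogen gives a 1.3-fold lower number from compound 2 to compound 4 (0.12 log units; within the scatter). The new group therefore cannot be placed on either side of the amino and hydrogen pair, even though those two differ beyond the scatter. Measured against the carboxy group, the change reads a 2.4-fold higher number from compound 1 to compound 4 (0.38 log units; beyond the scatter), a gap beyond the scatter that the amino triazole did not show, though no data here explain any of these numbers.

As far as these compounds go, it remains open whether a methyl group, a chlorine atom or a hydroxyl group on this carbon would separate from hydrogen or amino beyond the scatter. From the compounds shown here alone, it is equally open whether a tetrazole at the end of the methoxy arm would match the carboxy group.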